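The source may hold more compounds than are shown below. What is called first, only, known or untested is meant among the compounds shown, and "the series" means these compounds.

Among the measured compounds shown here, compound 1 `CCN(CC)S(=O)(=O)c1ccc(S(=O)(=O)N2CCC[C@@H](C(=O)N3CCC(O)CC3)C2)cc1` is one of two compounds measured in a functional assay on MIA PaCa-2 cells (Homo sapiens) for inhibition, read by MTT assay, with a stated time of 3 days; a lower number here means a stronger inhibitor, a higher number a weaker inhibitor; compound 1 gives 230 nM there, the higher of the two numbers. The other, compound 2 `CC(C)S(=O)(=O)c1ccc(S(=O)(=O)N2CCC[C@@H](C(=O)N3CCC(F)(F)CC3)C2)cc1`, gives 9.1 nM in this assay, a gap that lies beyond the scatter. Compound 3 `CCN(CC)S(=O)(=O)c1ccc(S(=O)(=O)N2CCC[C@@H](C(=O)N3CCC(COC)CC3)C2)cc1` departs from compound 1 by methoxymethyl in place of hydroxy on a saturated ring carbon. For the measured compounds named here, no measured pair shows this particular change, so its size is uncertain. A modest move toward a lower number is expected a 1.9-fold lower number from compound 1 to compound 3 (0.28 log units; within the scatter). Compound 3 is estimated at 120 nM in this assay, with a range from 40 nM to 400 nM.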

Compound 3, half-maximal inhibitory concentration: 50 nM
The estimate for compound 3 lay 2.4-fold (0.38 log units) above the measured number; measured number inside the range.
By their numbers in this assay, from the lowest: compound 2; then compound 3; then compound 1.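

In this assay, the saturated ring carbon three ring bonds from the ring nitrogen proves responsive to substitution: methoxymethyl in place of hydroxy gives a 4.6-fold lower number from compound 1 to compound 3 (0.66 log units; beyond the scatter). The hydrogen-bond donor of the hydroxy is therefore not required for activity in this series pair, as the entering group has none. No measurement available here explains the step.

As far as these compounds go, it remains open whether the change in the number follows the loss of the donor or the longer substituent. Hydroxymethyl, methoxy and an amine on this ring carbon lie outside the compounds shown.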